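Swapping Benzyl for Pyrrolidinyloxy in a Myeloperoxidase Inhibitor

This account rests on a few compounds, and the source may have more. Where it says the series, first, only, none or still open, it means among the compounds named here.

Compound 1 `Nc1cc(Cc2ccn(Cc3cccc(Cc4ccccc4)c3)n2)c2nn[nH]c2n1` was tested in an assay on isolated protein for inhibition of Myeloperoxidase (Homo sapiens), with a stated time of 10 min (on this read-out higher numbers stand for weaker inhibition and lower numbers for stronger inhibition), where compound 1 gives 39 nM. This is the higher of the two numbers available, yet compound 2 `Nc1cc(C2CCNCc3cccc(c3)COc3cccc(c3)Cn3cc2cn3)c2nn[nH]c2n1`, which in this assay gives 25 nM, sits so close that the two cannot be told apart. Compound 3 `Nc1cc(Cc2ccn(Cc3cccc(O[C@H]4CCNC4)c3)n2)c2nn[nH]c2n1` has not yet been measured. It differs from compound 1 in one place: (pyrrolidin-3-yl)oxy in place of benzyl on an aromatic carbon. For the measured compounds named here, no pair of measured compounds shows this change, so no measured step guides the estimate; the two measured values only show that rather different outer parts around the shared core give similar numbers. In this assay the expected step is a 1.1-fold lower number from compound 1 to compound 3 (0.05 log units; within the scatter), which is not expected to go beyond the usual scatter. The estimate for compound 3 is 35 nM, with a range from 10 nM to 120 nM.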

Compound 3, half-maximal inhibitory concentration: 46 nM
Compound 3: the middle estimate sits 1.3-fold (0.12 log units) below what was measured; low and high end bracket the measured number.
By their numbers in this assay, from the lowest: compounds 2, 1 and 3 (each within the scatter of the next).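

In this assay, for the compounds shown here, the change reads as a 1.2-fold higher number from compound 1 to compound 3 (0.07 log units; within the scatter), the first direct comparison at this position, since the earlier compounds offered no pair differing in one place. On this aromatic carbon, the benzyl group, with its six-membered aromatic ring of carbon only, and the (pyrrolidin-3-yl)oxy group, with its five-membered non-aromatic ring containing nitrogen, cannot be told apart by this read-out. Thus a large difference in the make-up of the group at this one place, including hydrogen-bond donors and acceptors and a defined stereocentre, goes with no step beyond the scatter. As far as these compounds go, whether the mirror-image form of the (pyrrolidin-3-yl)oxy group, a plain methoxy or a carboxylic acid on the same carbon would also read alike stays open. Nothing measured here explains why these two groups give such similar numbers.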